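A few compounds are considered here, and "the series" means these few. Any claim that something is new, unique, unknown or untested is made for them only; others in the source may bear on it.

Measured compounds in an assay on isolated protein for inhibition of sphingosine-1-phosphate lyase 1 (Homo sapiens), using Lineweaver-Burk analysis; on this read-out lower numbers stand for stronger inhibition and higher numbers for weaker inhibition:
- compound 1 `CCCCCCCCCCCCC/C=C/[C@H](O)[C@H](COP(=O)(O)O)N=[N+]=[N-]`: 20400 nM
- compound 2 `CCCCCCCCCCCCCCC[C@H](O)[C@H](COP(=O)(O)O)N=[N+]=[N-]`: 16400 nM
- compound 3 `CCCCCCCCCCCCCCC[C@@H](O)[C@H](COP(=O)(O)O)N=[N+]=[N-]`: 19000 nM

On the numbers shown, compound 1 nominally gives the highest of the three, but its gaps to compound 3 and to compound 2 are both within the scatter, so the three compounds cannot be separated in this assay.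

Compound 4 `CCCCCCCCCCCCC/C=C/[C@H](O)[C@@H](COP(=O)(O)O)N=[N+]=[N-]` is not yet measured. Relative to compound 1 the change is the two compounds have the same atoms and bonds; at least one stereo element is drawn with a configuration in one of them and without one in the other: 1 of 4 stereo elements differ; a stereocentre at a saturated chain carbon is drawn S in compound 1 and R in compound 4; nothing leaves and nothing enters, only the drawn configuration at that saturated chain carbon is turned over.

For the measured compounds named here, one measured step bears on this change: the pair compound 2 and compound 3, which differ in the same way at the same kind of centre, gave a 1.2-fold higher number from compound 2 to compound 3 (0.06 log units; within the scatter). Going by the values given here, that step is the only precedent, and it did not move the number beyond the scatter. For the step from compound 1 to compound 4 the expectation is therefore a change of similar size, that is none beyond the scatter, with no preferred direction; a 1.1-fold higher number from compound 1 to compound 4 (0.03 log units; within the scatter) is the expected step. Compound 4 is accordingly estimated at 22000 nM in this assay, with a range from 10000 nM to 45000 nM.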

Compound 4, inhibition constant: 5600 nM
Compound 4: the middle estimate sits 3.9-fold (0.59 log units) above what was measured, and the stated range ends above it.
By their numbers in this assay, from the lowest: compound 4; then compounds 2, 3 and 1 (each within the scatter of the next).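

In this assay, for the compounds shown here, turning over a single stereocentre produced the only step that lies beyond the scatter, a 3.6-fold lower number from compound 1 to compound 4 (0.56 log units; beyond the scatter), so the drawn configuration at this saturated chain carbon matters for inhibition, at least on the unsaturated chain of compound 1. The earlier step, a 1.2-fold higher number from compound 2 to compound 3 (0.06 log units; within the scatter), concerned a different stereocentre and stayed within the scatter, so it does not predict the effect at this one, and configuration in this series cannot be treated as uniformly silent; compounds 2 and 3 go against any such general reading. The modest step from a change that adds and removes no atoms rests on one stereochemical difference alone: the fact that one of compounds 1 and 4 is drawn with a defined configuration and the other without, at the place where they differ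

The compounds shown leave open whether the same turnover gives a comparable step on the saturated chain of compounds 2 and 3, and what lies behind the step. They also leave open whether the preference at this centre persists when the azide is replaced by an amine or the phosphate by a carboxylic acid.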